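Aryl carbonyl change from compound 3 to compound 4

This account rests on a few compounds, and the source may have more. Where it says the series, first, only, none or still open, it means among the compounds named here.

Measured so far in an ADME assay on SH-SY5Y cells (Homo sapiens) for cytotoxicity, read by MTT assay, with a stated time of 72 h; a lower number here means a stronger inhibitor, a higher number a weaker inhibitor
- compound 1 `COc1ccc2[nH]cc(CCCN3CCN(C(=O)CN4CCN(C(=O)c5ccc(Br)cc5)CC4)CC3)c2c1` gives 150000 nM as a number
- compound 2 `COc1ccc2[nH]cc(CCCN3CCN(C(=O)CN4CCN(C(=O)c5ccc(F)cc5)CC4)CC3)c2c1` gives > 200000 nM as a limit
- compound 3 `COc1ccc2[nH]cc(CCCN3CCN(C(=O)CN4CCN(C(=O)c5cccc(Cl)c5)CC4)CC3)c2c1` gives > 200000 nM as a limit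

Compound 3 has no number, only the limit > 200000 nM in this assay here. That places it at the limit of > 200000 nM in this assay, at which 2 of the 3 values shown sit, for these compounds. Compound 4 `COc1ccc2[nH]cc(CCCN3CCN(C(=O)CN4CCN(C(=O)c5ccccc5Br)CC4)CC3)c2c1` has 2-bromophenyl in place of 3-chlorophenyl on a carbonyl carbon, as counted in 2-bromophenyl in place of 3-chlorophenyl on a carbonyl carbon for this change. Going by the values given here, two measured steps bear on it, an at least 1.3-fold higher number from compound 1 to compound 2 (0.12 log units; that floor lies within the scatter) and an at least 1.3-fold higher number from compound 1 to compound 3 (0.12 log units; that floor lies within the scatter) as the only readable floors. The remaining one, a step that the two limits leave unreadable from compound 2 to compound 3, gives no size. Among the compounds with values here, no step beyond the scatter is expected, with a slight lean to a lower number because compound 1 with 4-bromophenyl gives 150000 nM as the only number so far. The expected move is an at least 1.1-fold lower number from compound 3 to compound 4 (0.07 log units; that floor lies within the scatter) by this estimate. For compound 4 the estimated value is 170000 nM, with an expected range from 80000 nM to 300000 nM in this assay.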

Compound 4, half-maximal inhibitory concentration: 111000 nM
Estimate against measurement, compound 4: 1.5-fold (0.19 log units) above, within the range that was stated.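

In this assay, 2-bromophenyl in place of 4-bromophenyl on the carbonyl carbon gives a 1.4-fold lower number from compound 1 to compound 4 (0.13 log units; within the scatter), so the two bromophenyl groups are not told apart here. Against the other two aryl groups, the steps are an at least 1.8-fold lower number from compound 3 to compound 4 (0.25 log units; that floor lies within the scatter) and an at least 1.8-fold lower number from compound 2 to compound 4 (0.25 log units; that floor lies within the scatter), and these floors do not separate them from 2-bromophenyl. Both bromophenyl compounds carry numbers, while the 4-fluorophenyl and 3-chlorophenyl compounds stay at a limit: the limit of > 200000 nM in this assay, at which 2 of the 4 values shown sit.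

The step between those two limits cannot be read. From the compounds shown here alone, whether an amine or a carboxylic acid on the phenyl ring would move the value beyond the scatter remains open.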